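A few compounds are considered here, and "the series" means these few. Any claim that something is new, unique, unknown or untested is made for them only; others in the source may bear on it.

Measured so far in a functional assay on PC-3 cells (Homo sapiens) for cytotoxicity; on this read-out lower numbers stand for stronger inhibition and higher numbers for weaker inhibition:
- Compound 1 `Oc1ccccc1/C=N/n1cnnc1`: > 30000 nM
- Compound 2 `COc1cccc(/C=N/n2cnnc2)c1O`: > 30000 nM

In this assay compound 2 gives > 30000 nM, which is a limit of the assay and not a number. Compound 1 gives > 30000 nM, which is also a limit. Neither compound therefore has an exact position, and the evidence so far is the limit of > 30000 nM in this assay, at which 2 of the 2 values shown sit.

Compound 3 `CCOc1cccc(/C=N/n2cnnc2)c1O` is the next compound to consider. It carries one small change from compound 2: methyl in place of hydrogen on a saturated chain carbon bound to an oxygen on an aromatic ring. In other words, methoxy becomes ethoxy.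

Going by the values given here, the one measured step that bears on this change is a step that the two limits leave unreadable from compound 1 to compound 2. It placed a methoxy in place of hydrogen on an aromatic carbon, and its size cannot be read from the two limits. It therefore offers no sign of a gain in this assay, and no step beyond the scatter is expected. Compound 3 is expected to stay at the same assay limit.

The estimated change is a step that the limit leaves unreadable from compound 2 to compound 3. For compound 3 the estimated value is 35000 nM, with an expected range from 12000 nM to 80000 nM.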

Compound 3, half-maximal inhibitory concentration: > 30000 nM
Compound 3: only a limit was reported (the forecaster's own chance of this, stated with the estimate: 85%); the middle value does not contradict the limit.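

In this assay compound 3 gives > 30000 nM, which is a limit and not a number. Compound 1 and compound 2 sit at the same limit, so no step among these three compounds can be read: the limit of > 30000 nM in this assay, at which 3 of the 3 values shown sit.

The compounds shown leave open whether hydrogen, methoxy or ethoxy at this place makes any difference to the true potency in this assay.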